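A few compounds are considered here, and "the series" means these few. Any claim that something is new, unique, unknown or untested is made for them only; others in the source may bear on it.

Compound 1 `COc1cc(OCc2cccc(-c3ccc(C(F)(F)F)cn3)c2)c2cc(-c3cn4nc(OC)sc4n3)oc2c1` is the starting point of this step, and the read-out that matters here is an ADME assay on microsomes from liver (Homo sapiens) for metabolic stability; on this read-out lower numbers stand for a shorter-lived compound and higher numbers for a longer-lived compound. In this assay, among the compounds with values here, compound 1 gives 0.733 h, the only value in the set that is reported as a number. Compound 2 `COc1cc(OCc2csc(-c3ccc(C(=O)O)cc3)n2)c2cc(-c3cn4nc(OC)sc4n3)oc2c1` shares the core of compound 1 but carries a different arm on the benzyl ether. In this assay compound 2 reaches > 2 h, which is a limit of the assay and not a number. Compound 2 therefore sits at the limit of > 2 h in this assay, at which 1 of the 2 values shown sits. Within the data shown here, no pair of measured compounds differs in a single place, so no step size between measured compounds is available, and the values of compound 1 and compound 2 can only be set side by side.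

Compound 3 `COc1cc(OCc2cccc(-c3cnc(OC)cn3)c2)c2cc(-c3cn4nc(OC)sc4n3)oc2c1` has not yet been measured. It differs from compound 1 by 5-methoxypyrazin-2-yl in place of 5-(trifluoromethyl)pyridin-2-yl on an aromatic carbon. Among the measured compounds shown here, with no measured step to lean on, the expectation for the step of a 1.2-fold lower number from compound 1 to compound 3 (0.09 log units; within the scatter) is that it stays within the usual scatter, leaning slightly toward a shorter-lived compound. Compound 3 is expected to give 0.6 h in this assay, estimated to fall between 0.3 h and 1.4 h.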

Compound 3, half-life: 1.48 h
For compound 3 the middle estimate is 2.5-fold (0.39 log units) below the measured one; the measured number lies above the stated range.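

In this assay, within the data shown here, this is the first change in the set that can be read as a step: a 2.0-fold higher number from compound 1 to compound 3 (0.31 log units; beyond the scatter) comes with 5-methoxypyrazin-2-yl in place of 5-(trifluoromethyl)pyridin-2-yl, on an aromatic carbon meta to a large group. It shows that, with the shared core held fixed, exchanging the ring at this position moves the half-life beyond the usual scatter, though only modestly, and toward a longer-lived compound. The change replaces trifluoromethyl with methoxy and adds a second hetero atom to the ring at the same time, and no measurement given here bears on why the half-life moves or on which of these two differences matters.

Left open is which of the two differences carries the step, a question that 5-methoxypyridin-2-yl or 5-(trifluoromethyl)pyrazin-2-yl at this place would separate. Also open, on these data alone, is whether a simple amine on this ring would carry the half-life further, and compound 2, whose value is a limit, differs from compound 1 in more than one place and gives no reading of this change.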